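From Fluoro to Bromo in a Cytotoxicity Series

The source may report more compounds than this note shows. Statements on the series, on what has been measured and on what is new or still open speak of the compounds shown alone.

In a functional assay on C8166 cells (Homo sapiens) for cytotoxicity, read by MTT assay, with a stated time of 72 h (a higher number here means that more compound is tolerated, a lower number that less compound is tolerated), compound 1 `Cc1nc2ccccc2n(CC(=O)N/N=C/c2ccc(N(C)C)cc2)c1=O` gives 355000 nM and compound 2 `Cc1ccc(S(=O)(=O)N2CC3(C[C@H]2C(=O)N/N=C/c2ccccc2F)SCCS3)cc1` gives 280000 nM and these two numbers lie within the usual scatter of each other. Compound 3 `COc1cc(/C=N/NC(=O)Cn2c(=O)c(C)nc3ccccc32)cc(OC)c1OC` gives > 487000 nM which is a limit and not a number. The change leading to compound 4 `Cc1ccc(S(=O)(=O)N2CC3(C[C@H]2C(=O)N/N=C/c2ccccc2Br)SCCS3)cc1` is bromo in place of fluoro on an aromatic carbon and it falls on an aromatic carbon of a six-membered aromatic ring of carbon only, ortho to a large group. Among the measured compounds shown here, no measured pair shows this swap, so starting from compound 2 at 280000 nM only a small step toward a lower number is expected in this assay and it may stay within the scatter. The expected change is a 1.4-fold lower number from compound 2 to compound 4 (0.15 log units; within the scatter) in this estimate. For compound 4 the estimate is 200000 nM with an expected range from 90000 nM to 360000 nM in the same read-out.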

Compound 4, half-maximal cytotoxic concentration: 177000 nM
Beside the measured number, compound 4's estimate is 1.1-fold (0.05 log units) above it; measured number inside the range.
By their numbers in this assay, from the lowest: compounds 4, 2 and 1 (each within the scatter of the next). At a limit, above all of these: compound 3.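

Among the compounds shown here, this is the first step read at this position: on an aromatic carbon ortho to a large group, in this assay, bromo in place of fluoro gives a 1.6-fold lower number from compound 2 to compound 4 (0.20 log units; within the scatter), so the two halogens are not told apart here. Compound 3 alone stands at a limit, which is not a number: the limit of > 487000 nM in this assay, at which 1 of the 4 values shown sits.

The compounds shown leave open whether another group at this place, such as an amine or a carboxylic acid, would give a step beyond the scatter. As far as these compounds go, whether the same swap reads alike on another core also stays open.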